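Dropping the basic tail: from compound 3 to compound 4

This account rests on a few compounds, and the source may have more. Where it says the series, first, only, none or still open, it means among the compounds named here.

Measured so far:
- Compound 1 `CCN(CC)CCCC(C)/N=C(/N)NC(=O)c1cccc(Cl)c1CCc1cc(Br)ccc1OC` — 260 nM
- Compound 2 `COc1ccc(Br)cc1CCc1c(F)cccc1C(=O)/N=C(\N)NCCC1CCCCC1` — "not determined" (no result reported)
- Compound 3 `COc1ccc(Br)cc1CCc1c(F)cccc1C(=O)/N=C(\N)NCCCCN1CCCCC1` — 70 nM

All three compounds share a core in which an amidine is joined to an aromatic amide, and they differ in the chain that hangs from the amidine nitrogen. In a functional assay for antagonist activity at Melanocortin receptor 4 (Homo sapiens), read by cAMP accumulation (a higher number here means a weaker inhibitor, a lower number a stronger inhibitor), compound 1 gives 260 nM, while compound 3 gives 70 nM, the lower of the two numbers and therefore the stronger inhibitor, with the gap between them beyond the usual scatter. For compound 2 this assay gave "not determined" (no result reported), so no number is available there.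

Compound 4 `COc1ccc(Br)cc1CCc1c(F)cccc1C(=O)/N=C(\N)NCC(C)C` is the next step from compound 3. The change is isopropyl in place of 3-(piperidin-1-yl)propyl on a saturated chain carbon bound to an amine nitrogen. Both compounds with a number carry a chain ending in an amine; compound 4 loses that, so the expectation is a move toward a higher number, beyond the scatter. Compound 4 is therefore expected to give 500 nM, within a range of 120 nM to 2500 nM, a step of a 7.1-fold higher number from compound 3 to compound 4 (0.85 log units; beyond the scatter) expected.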

Compound 4, half-maximal inhibitory concentration: 8500 nM
Compound 4: the middle estimate sits 17-fold (1.23 log units) below what was measured; measured number above the stated range.
By their numbers in this assay, from the lowest: compound 3; then compound 1; then compound 4.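

In this assay, putting isopropyl in place of 3-(piperidin-1-yl)propyl on a saturated chain carbon bound to an amine nitrogen gives a 120-fold higher number from compound 3 to compound 4 (2.08 log units; beyond the scatter), a large loss of inhibition. For the compounds shown here, this is the first reading of this place with the rest of the molecule held constant, since compound 1 differs from compound 3 in more than one place, and it shows that the long piperidine-bearing chain matters greatly here. No measured evidence explains the size of this step.

As far as these compounds go, the change removes the ring, its nitrogen and much of the chain at once, so the contribution of each remains unknown. A chain of the same length ending in a dimethylamine or a cyclohexane ring would help separate them, and compound 2 offers no number to settle this.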